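Replacing a chloro with a methyl on the benzyl ring

The source may hold more compounds than are shown below. What is called first, only, known or untested is meant among the compounds shown, and "the series" means these compounds.

Of the compounds shown here, three on a shared core have so far been measured in a functional assay on spleen for antagonist activity at Alpha-1B adrenergic receptor (Rattus norvegicus); a lower number here means a less potent compound, a higher number a more potent compound, by a factor of ten per unit of this negative logarithm. Compound 1 `COc1cccc(OC)c1OCCNCCOc1ccccc1OCc1ccccc1` gives 8.3. Compound 2 `COc1cccc(OC)c1OCCNCCOc1ccccc1OCc1cccc(Cl)c1` gives 7.93, and compound 3 `COc1cccc(OC)c1OCCNCCOc1ccccc1OCc1ccc(Cl)cc1` gives 8.06. Compound 2 carries the lowest of the three numbers: its distance to compound 1, read as a number 0.37 log units lower from compound 1 to compound 2 (beyond the scatter), lies beyond the scatter, while its distance to compound 3, read as a number 0.13 log units higher from compound 2 to compound 3 (within the scatter), stays within it.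

Compound 4 `COc1cccc(OC)c1OCCNCCOc1ccccc1OCc1ccccc1C` differs from compound 2 by 2-methylphenyl in place of 3-chlorophenyl on a saturated chain carbon bound to an oxygen on an aromatic ring. For the measured compounds named here, no measured step puts a methyl on that ring; what bears on the change are the steps that place or move a chloro there. From the unsubstituted parent, a number 0.37 log units lower from compound 1 to compound 2 (beyond the scatter) and a number 0.24 log units lower from compound 1 to compound 3 (within the scatter) both point modestly downward, and the move of the chloro, a number 0.13 log units higher from compound 2 to compound 3 (within the scatter), changes little. Substituents on this ring have therefore shifted the number only slightly, and the unsubstituted compound 1 stands highest.

The step from compound 2 to compound 4 is accordingly expected to be small, a number 0.17 log units higher from compound 2 to compound 4 (within the scatter), not clearly beyond the scatter. Compound 4 is estimated at 8.1, in a range from 7.6 to 8.6.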

Compound 4, negative logarithm of the antagonist equilibrium constant: 7.67
The estimate for compound 4 lay 0.43 log units above the measured number; the range from low to high includes it.
By their numbers in this assay, from the lowest: compounds 4, 2, 3 and 1 (each within the scatter of the next, the first and the last beyond it).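

In this assay the step of a number 0.63 log units lower from compound 1 to compound 4 (beyond the scatter) is the widest yet seen from the unsubstituted parent, and it comes from a methyl alone placed on the ring of the benzyl group. Against the two chloro compounds the result splits: the step of a number 0.39 log units lower from compound 3 to compound 4 (beyond the scatter) clears the scatter, while the step of a number 0.26 log units lower from compound 2 to compound 4 (within the scatter) does not, so this position now shows a spread that the chloro pair, within the scatter of each other, did not show on their own. Nothing available here gives a reason for these steps.

As far as these compounds go, compound 4 differs from compound 2 and compound 3 in both the group and its place on the ring, and these compounds cannot separate the two, so it stays open whether the lower number goes with the methyl or with where it sits. From the compounds shown here alone, how a hydroxyl, an amine or a carboxylic acid on this same ring would read in this assay also remains open, as does whether any group there can match the unsubstituted compound 1.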